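The source may hold more compounds than are shown below. What is called first, only, known or untested is meant among the compounds shown, and "the series" means these compounds.

Among the measured compounds shown here, compound 1 `Nc1cc(N)c2nc(-c3ccccc3)c(NCc3ccc(Cl)c(Cl)c3)nc2c1` is the only member of this set with a measured number in a functional assay on SW-620 cells (Homo sapiens) for inhibition, read by sulforhodamine B assay, with a stated time of 48 h; on this read-out lower numbers stand for stronger inhibition of growth and higher numbers for weaker inhibition of growth: compound 1 gives 9770 nM. Compound 2 `CCOC(=O)[C@H](CCC(=O)O)NC(=O)c1ccc(Oc2nc3cc(N)cc(N)c3nc2-c2ccccc2)cc1` is recorded differently, as a limit of the assay rather than a number, with compound 2 reported at < 100000 nM. Only one entry, (the limit of < 100000 nM in this assay, at which 1 of the 2 values shown sits), is such a limit, and it carries no number that could be compared with compound 1. The next compound, compound 3 `COc1ccc(CNc2nc3cc(N)cc(N)c3nc2-c2ccccc2)cc1`, has not yet been measured; it differs from compound 1 by 4-methoxyphenyl in place of 3,4-dichlorophenyl on a saturated chain carbon bound to a nitrogen on an aromatic ring. For the measured compounds named here, no measured pair in this set shows a change of this kind, so its size and direction cannot be read from the data. A modest step is expected, leaning if anything towards weaker inhibition of growth, though it may well stay within the scatter of repeated measurements. The expected step is a 1.5-fold higher number from compound 1 to compound 3 (0.19 log units; within the scatter). For compound 3 in this assay the expected value is 15000 nM, with a range from 5000 nM to 50000 nM.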

Compound 3, concentration for total growth inhibition: 30200 nM
For compound 3 the middle estimate is 2.0-fold (0.30 log units) below the measured one; the range from low to high includes it.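

Among the compounds shown here, this is the first measured step at this place, on a saturated chain carbon bound to a nitrogen on an aromatic ring: in this assay, putting 4-methoxyphenyl in place of 3,4-dichlorophenyl gives a 3.1-fold higher number from compound 1 to compound 3 (0.49 log units; beyond the scatter). The read-out therefore tells these two groups apart, even though each has the same count of heavy atoms and one six-membered aromatic ring of carbon only, and the 3,4-dichlorophenyl group gives the stronger inhibition of growth of this pair. The change removes two chlorine atoms and adds a methoxy group in a single step, so this pair alone cannot show which part of the change matters.

Still open, from the compounds shown here alone, is how a plain phenyl, a 4-chlorophenyl or an aminophenyl group would read at this place. Nothing measured in this set explains the step.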